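A Larger Five-Membered Ring Group in a Carbamate Series

The source may hold more compounds than are shown below. What is called first, only, known or untested is meant among the compounds shown, and "the series" means these compounds.

Three carbamate-bearing compounds were measured in an assay on membranes from cerebellum (strain Wistar) for inhibition of Monoglyceride lipase (Rattus norvegicus), read by HPLC, tested at 100 uM; on this read-out lower numbers stand for less inhibition and higher numbers for more inhibition at the one concentration tested (going by the name of the read-out). Compound 1 `CCCNC(=O)Oc1cccc(-c2nc3ccccc3o2)c1` gives 26% in this assay, and compound 2 `CCCNC(=O)Oc1cccc(-c2nc3ncccc3o2)c1` gives 29%. Compound 3 `O=C(NC1CCCCC1)Oc1cccc(C2=NCCO2)c1` gives 22% in this assay; its number sits within the scatter of both compound 1 and compound 2, so the three cannot be told apart on these readings.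

Compound 4 `CC1(C)COC(c2cccc(OC(=O)NC3CCCCC3)c2)=N1` has not been measured. It differs from compound 3 in one place: a group of 7 heavy atoms (5 carbon, 1 nitrogen, 1 oxygen; one five-membered non-aromatic ring with 2 hetero atoms) in place of a group of 5 heavy atoms (3 carbon, 1 nitrogen, 1 oxygen; one five-membered non-aromatic ring with 2 hetero atoms), on an aromatic carbon. Among the compounds with values here, the ring that enters carries more carbon than the one that leaves, but the count of donors and acceptors is unchanged, and no measured pair shows what such an exchange does in this assay.

With nothing in the data to point either way, the step expected from compound 3 to compound 4 is a number 2 percentage points higher from compound 3 to compound 4 (within the scatter), which is no move beyond the scatter. Compound 4 is therefore estimated to give about 24% in this assay, with a range from 10% to 40%.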

Compound 4, a percentage reported as inhibition, at one concentration (the size of the read-out at that concentration, not a potency): 20%
For compound 4 the middle estimate is 4 percentage points above the measured one; the range from low to high includes it.
By their numbers in this assay, from the lowest: compounds 4, 3, 1 and 2 (each within the scatter of the next).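

In this assay, the ring of 7 heavy atoms in place of the ring of 5 heavy atoms, on an aromatic carbon meta to a large group, gives a number 2 percentage points lower from compound 3 to compound 4 (within the scatter) and is the only step that can be read among these compounds. It shows that, at this position, a five-membered non-aromatic ring with 2 hetero atoms can carry more carbon without a move beyond the scatter. No measurement shown bears on the reason for this.

Going by these compounds, what an amine or a carboxylic acid would do in place of this ring remains open, as does the effect of a longer chain on the carbamate nitrogen. On these data alone, each reading comes from a single concentration, so the potency of compound 3 and compound 4 also remains unknown.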